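The source may hold more compounds than are shown below. What is called first, only, known or untested is meant among the compounds shown, and "the series" means these compounds.

Measured compounds:
compound 1, `COc1cccc(/C=C2\CCC/C(=C\c3ccc(Br)cc3)C2=O)c1OC`, 13800 nM
compound 2, `COc1ccc(/C=C2\CCC/C(=C\c3ccccc3Br)C2=O)cc1OC`, 9500 nM

Both compounds were tested in a functional assay on MCF7 cells (Homo sapiens) for cytotoxicity, read by MTT assay, with a stated time of 72 h; on this read-out lower numbers stand for stronger inhibition and higher numbers for weaker inhibition. Among the compounds with values here, the two numbers lie within the usual scatter of each other, so on these data compound 2 and compound 1 cannot be told apart; compound 2 simply stands as one of two closely spaced readings, with no step between them that can be called real.

Compound 3, `COc1ccc(/C=C2\CCC/C(=C\c3ccc(Cl)c(Cl)c3)C2=O)cc1OC`, has not yet been measured in this assay. It differs from compound 2 in one place: 3,4-dichlorophenyl in place of 2-bromophenyl on a double-bonded chain carbon bound to a double-bonded ring carbon. The shared core, including the chain carbon that carries the changed ring, is untouched.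

No measured pair in this set shows what such a swap of one substituted phenyl for another does in this assay, so there is no shown step to lean on. Within the data shown here, with only two readings available, and those two inside the scatter, the expected step is none beyond the scatter: compound 3 is expected to land near its neighbours, with a 1.1-fold lower number from compound 2 to compound 3 (0.05 log units; within the scatter) as the estimated change. The estimated value for compound 3 is 8500 nM, with an expected range from 3000 nM to 25000 nM.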

Compound 3, half-maximal inhibitory concentration: 4400 nM
Compound 3: middle estimate off by 1.9-fold (0.29 log units), on the high side; low and high end bracket the measured number.
By their numbers in this assay, from the lowest: compound 3; then compounds 2 and 1 (each within the scatter of the next).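

In this assay, within the data shown here, the substituted phenyl on a double-bonded chain carbon bound to a double-bonded ring carbon proves able to shift the reading: there is a 2.2-fold lower number from compound 2 to compound 3 (0.33 log units; beyond the scatter), the only step in this set that lies beyond the scatter, though it is modest. The earlier pair of readings could not show this, since those two compounds differ in more than one place and sit within the scatter of each other, whereas here the shared core stays the same and only 3,4-dichlorophenyl replaces 2-bromophenyl. No measurement at hand explains why the number moves.

This single swap changes the kind of halogen and the number of halogen atoms together, so it cannot show whether either change alone would give the same step. Also open, going by these compounds, is how this place responds to groups other than halogens, such as an amine, a carboxylic acid or a longer chain on the phenyl ring, and whether the step would hold with a different arrangement of groups on the other ring of the shared core.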